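Alkyne-linked phenoxyacetic acids: a thiazole in place of chloro

The source may report more compounds than this note shows. Statements on the series, on what has been measured and on what is new or still open speak of the compounds shown alone.

Measured so far:
compound 1 `CS(=O)(=O)c1ccc(F)c(C#Cc2cc(Cl)ccc2OCC(=O)O)c1`, 3.3 nM
compound 2 `CCCc1ccncc1C#Cc1cc(Cl)ccc1OCC(=O)O`, 4.3 nM
compound 3 `CCCS(=O)(=O)c1cccc(C#Cc2c(Cl)cccc2OCC(=O)O)c1`, 55 nM

All three numbers come from an assay on CHO cells for displacement of a labelled ligand from prostaglandin D2 receptor 2 (Homo sapiens), read by scintillation counting; a lower number here means a stronger inhibitor, a higher number a weaker inhibitor. Compound 1 gives 3.3 nM and compound 2 gives 4.3 nM, two values that lie within the scatter of each other. Compound 3 gives 55 nM, the highest of the three numbers; its gap to compound 2 and its gap to compound 1 both lie beyond the scatter, so compound 3 is the weakest inhibitor of the set as measured. No two of the measured compounds differ in a single place, so no measured step can be read off.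

Compound 4 `CCCS(=O)(=O)c1cccc(C#Cc2c(OCC(=O)O)cccc2-c2sc(C)nc2C)c1` is not yet measured. It differs from compound 3 in one place: 2,4-dimethyl-1,3-thiazol-5-yl in place of chloro on an aromatic carbon, on an aromatic carbon of a six-membered aromatic ring of carbon only, ortho to a large group and meta to a carboxymethoxy group. Among the compounds with values here, no measured pair shows what such an exchange does in this assay, so the direction of the step is open. The working expectation is a modest move toward a lower number, a 2.8-fold lower number from compound 3 to compound 4 (0.44 log units; beyond the scatter), with wide uncertainty in both directions. Compound 4 is therefore estimated at 20 nM, within the range 4 nM to 100 nM.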

Compound 4, inhibition constant: 54 nM
Compound 4: the middle estimate sits 2.7-fold (0.43 log units) below what was measured, within the range that was stated.
By their numbers in this assay, from the lowest: compounds 1 and 2 (each within the scatter of the next); then compounds 4 and 3 (each within the scatter of the next).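

In this assay, 2,4-dimethyl-1,3-thiazol-5-yl in place of chloro gives a 1.0-fold lower number from compound 3 to compound 4 (0.01 log units; within the scatter), so the two numbers cannot be told apart. Within the data shown here, on this aromatic carbon, ortho to a large group and meta to a carboxymethoxy group, a single chlorine atom can therefore give way to a five-membered aromatic ring with 2 hetero atoms and 2 hydrogen-bond acceptors with no measurable cost in this pair, something the earlier compounds could not show because none of them differed in one place. Nothing at hand explains why the numbers match.

As far as these compounds go, whether hydrogen, a methoxy group or a plain phenyl ring at this carbon would give a similar number remains open, as does the part played by the two methyl groups on the thiazole. Steps linking compound 3 or compound 4 to compound 1 or compound 2 cannot be read, so whether the same exchange would give a similar result on the core of either of those compounds also stays open.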